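A few compounds are considered here, and "the series" means these few. Any claim that something is new, unique, unknown or untested is made for them only; others in the source may bear on it.

Compound 1 `CCCCCCCOc1ccc(NC(=O)Oc2ccccc2F)cc1` gives 28 nM in an assay on H4 cells for inhibition of Fatty-acid amide hydrolase 1 (Homo sapiens) (on this read-out higher numbers stand for weaker inhibition and lower numbers for stronger inhibition), and compound 2 `CCCCCCCCOc1ccc(NC(=O)Oc2ccccc2F)cc1` gives 19 nM in this assay; the change between them, a methyl in place of hydrogen far along the saturated chain, moves the number by a 1.5-fold lower number from compound 1 to compound 2 (0.17 log units; within the scatter). Compound 3 `CCCCOc1ccc(C(CC)NC(=O)Oc2ccc(OC)cc2)cc1` gives 12 nM. Among these three numbers compound 2 stands second highest, yet its gaps to compound 1 and to compound 3 both lie within the scatter, so no order among them can be claimed.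

Compound 4 `CCCCCCCCOc1ccc(NC(=O)ON=C(C)C)cc1` differs from compound 2 at the carbamate end: a group of 4 heavy atoms (3 carbon, 1 nitrogen; no ring) in place of a group of 7 heavy atoms (6 carbon, 1 fluorine; one six-membered aromatic ring of carbon only), on an oxygen next to a carbonyl group. For the measured compounds named here, no measured step touches this part of the molecule, since the single step, from compound 1 to compound 2, concerns only the chain. The expectation for compound 4 therefore rests on little, and a somewhat higher number is estimated, with a wide range, namely an estimated step of a 4.2-fold higher number from compound 2 to compound 4 (0.62 log units; beyond the scatter). Compound 4 is expected to give about 80 nM in this assay, estimated to fall between 15 nM and 500 nM.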

Compound 4, half-maximal inhibitory concentration: 2.4 nM
For compound 4 the middle estimate is 33-fold (1.52 log units) above the measured one; the measured number lies below the stated range.
By their numbers in this assay, from the lowest: compound 4; then compounds 3, 2 and 1 (each within the scatter of the next, the first and the last beyond it).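

In this assay, for the compounds shown here, this result is the first look at the group on an oxygen next to a carbonyl group, and replacing 2-fluorophenyl there with a smaller group that has no ring gives a 7.9-fold lower number from compound 2 to compound 4 (0.90 log units; beyond the scatter) and does not weaken inhibition. Unlike the chain change between compound 1 and compound 2, this change moves the number beyond the scatter, so this end of the molecule matters more in the compounds shown. At least for this pair, an aromatic ring at this place is not needed for a low number, but no measurement here accounts for the size of the step.

Going by these compounds, it remains open whether other groups on this oxygen, such as a cyclohexyl ring or a plain ethyl chain, would give a similar number. On these data alone, it is also open whether the same change would have a similar effect on the shorter chain of compound 1.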